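Carbamate to urea swap on the shared core

The source may hold more compounds than are shown below. What is called first, only, known or untested is meant among the compounds shown, and "the series" means these compounds.

Measured in an assay on isolated protein for inhibition of Gonadotropin-releasing hormone receptor (Rattus norvegicus); on this read-out higher numbers stand for weaker inhibition and lower numbers for stronger inhibition:
compound 1 `COc1ccc([N+](=O)[O-])cc1CSc1nc2cc(NC(=O)NC(C)(C)C)ccc2n1-c1ccccc1` gives > 2600 nM
compound 2 `COc1ccc([N+](=O)[O-])cc1CSc1nc2cc(NC(=O)OC(C)(C)C)ccc2n1C(C)C` gives 710 nM

Among the compounds with values here, compound 2 carries the only number in this assay. For compound 1 the value is a limit of the assay, not a number: the limit of > 2600 nM in this assay, at which 1 of the 2 values shown sits. Compound 3 `COc1ccc([N+](=O)[O-])cc1CSc1nc2cc(NC(=O)NC(C)(C)C)ccc2n1C(C)C` differs from compound 2 by (tert-butyl)amino in place of tert-butoxy on a carbonyl carbon. Within the data shown here, no measured pair isolates this change, and compound 1 differs from compound 2 in two places, so its limit alone does not fix the step. A weakening beyond the scatter is expected for compound 3, a 2.3-fold higher number from compound 2 to compound 3 (0.35 log units; beyond the scatter). Compound 3 is estimated at 1600 nM, between 450 nM and 6000 nM.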

Compound 3, half-maximal inhibitory concentration: 62 nM
For compound 3 the middle estimate is 26-fold (1.41 log units) above the measured one; measured number below the stated range.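

In this assay, (tert-butyl)amino in place of tert-butoxy on a carbonyl carbon gives an 11-fold lower number from compound 2 to compound 3 (1.06 log units; beyond the scatter) with isopropyl held on the aromatic nitrogen, so this change strengthens inhibition on the shared core. Isopropyl in place of phenyl on an aromatic nitrogen gives an at least 41-fold lower number from compound 1 to compound 3 (1.62 log units; beyond the scatter) with the urea held constant, so that position also matters strongly. The figure for compound 1 is a limit of the assay, not a number: the limit of > 2600 nM in this assay, at which 1 of the 3 values shown sits.

From the compounds shown here alone, whether the gain holds with a dimethylamino or cyclohexylamino group on the carbonyl carbon remains open. So does the response to ethyl or cyclopentyl on the aromatic nitrogen.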